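Antiproliferative series: one aryl group change at compound 3

The compounds below may be only part of what the source reports. "The series", "measured", "known", "first", "only" and "open" are said of these compounds alone.

Compound 1 `COc1cc2ncnc(Nc3ccccc3)c2cc1OCCCCC(=O)Nc1ccc(S(N)(=O)=O)cc1` gives > 40000 nM
Compound 2 `NS(=O)(=O)c1ccc(NC(=S)Nc2ccc3ncnc(Nc4ccc(Cl)c(C(F)(F)F)c4)c3c2)cc1` gives 4500 nM

Compound 1 stands at > 40000 nM in a functional assay on A549 cells (Homo sapiens) for antiproliferative activity, read by MTT assay, with a stated time of 72 h (a lower number here means a stronger inhibitor, a higher number a weaker inhibitor), as a limit and not a number. For the measured compounds named here, compound 2, at 4500 nM in this assay, therefore holds the only true number so far.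

Compound 3 `NS(=O)(=O)c1ccc(NC(=S)Nc2ccc3ncnc(Nc4cccc(Cl)c4)c3c2)cc1` has not yet been measured. It carries 3-chlorophenyl in place of 4-chloro-3-(trifluoromethyl)phenyl on a nitrogen on an aromatic ring and is otherwise the same as compound 2.

Going by the values given here, no measured step in this assay speaks to this change, so the expectation rests only on compound 2 at 4500 nM and the change itself. No step beyond the usual scatter is expected, in either direction. The estimated step is a 1.2-fold higher number from compound 2 to compound 3 (0.09 log units; within the scatter) in size, with wide uncertainty given so little data. Compound 3 is expected at 5500 nM with an estimated range from 1800 nM to 16000 nM in this assay window.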

Compound 3, half-maximal inhibitory concentration: > 40000 nM
Compound 3 ended at the assay's limit (the forecaster's own chance of this, stated with the estimate: 5%); middle value at least 7.2-fold (0.86 log units) from the limit.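

In this assay, for the compounds shown here, the aryl group on a nitrogen on an aromatic ring gives the first single-place comparison: 3-chlorophenyl in place of 4-chloro-3-(trifluoromethyl)phenyl gives an at least 8.8-fold higher number from compound 2 to compound 3 (0.94 log units; beyond the scatter). Compound 3 gives > 40000 nM, which is a limit and not a number. This position is therefore not indifferent to the aryl group, and within this pair only the 4-chloro-3-(trifluoromethyl)phenyl group gives a measurable value, though the true size of the step stays unfixed: the limit of > 40000 nM in this assay, at which 2 of the 3 values shown sit.

The change removes the trifluoromethyl group and also alters the chlorine substitution, so the compounds shown do not separate these two parts of it. Also open, as far as these compounds go, is whether the trifluoromethyl group itself is needed, or whether a phenyl group carrying a nitrile or a methoxy group on the same nitrogen would give a value inside the assay's range.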